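The source may report more compounds than this note shows. Statements on the series, on what has been measured and on what is new or still open speak of the compounds shown alone.

Compound 1 `COc1ccc(C2CC(c3ccccc3)=NN2c2nc(-c3ccccc3)c(C#N)c(=O)n2C)cc1` gives 12800 nM in a functional assay on MDA-MB-231 cells (Homo sapiens) for antiproliferative activity, with a stated time of 72 h; a higher number here means a weaker inhibitor, a lower number a stronger inhibitor. Compound 2 `COc1ccc(C2=NN(c3nc(-c4ccccc4)c(C#N)c(=O)n3C)C(c3ccc(OC)cc3)C2)cc1`, which carries the change (methoxy in place of hydrogen on an aromatic carbon), gives 16200 nM in this assay, and the step of a 1.3-fold higher number from compound 1 to compound 2 (0.10 log units; within the scatter) is a small one. Compound 3 `Cn1c(N2N=C(c3ccc(Cl)cc3)CC2c2ccccc2)nc(-c2ccc(Cl)cc2)c(C#N)c1=O` gives 12400 nM in this assay; the difference between the core of compound 3 and the core of compound 1 is not broken down here. Compound 4 `COc1ccc(C2CC(c3ccc(Cl)cc3)=NN2c2nc(-c3ccc(Cl)cc3)c(C#N)c(=O)n2C)cc1` remains to be measured and carries the change methoxy in place of hydrogen on an aromatic carbon relative to compound 3, the same change at the same place as that seen between compound 1 and compound 2; it occurs twice among these compounds. Since the earlier step was a 1.3-fold higher number from compound 1 to compound 2 (0.10 log units; within the scatter), the step of a 1.2-fold higher number from compound 3 to compound 4 (0.08 log units; within the scatter) is expected to be similarly small. Compound 4 is accordingly estimated at 15000 nM in this assay, with an expected range from 7000 nM to 32000 nM.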

Compound 4, half-maximal inhibitory concentration: 24800 nM
Compound 4: the middle estimate sits 1.7-fold (0.22 log units) below what was measured, and the stated range covers the measured number.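

On the core of compound 3, methoxy in place of hydrogen on an aromatic carbon gives a 2.0-fold higher number from compound 3 to compound 4 (0.30 log units; within the scatter). Set beside the earlier step, the change carries across the two cores without a difference that can be read in this assay: the same change on two cores in this assay, a 1.3-fold higher number (0.10 log units; within the scatter) from compound 1 to compound 2 and a 2.0-fold higher number (0.30 log units; within the scatter) from compound 3 to compound 4, 1.6-fold (0.20 log units) apart, within the scatter of two such steps. This shows only that phenyl to 4-methoxyphenyl stays within the scatter on these two cores; it does not show that the two steps are equal, nor does it set a rule for other cores in the series.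

As far as these compounds go, it remains open whether an amine, a carboxylic acid or a longer alkoxy chain at this place would move the number beyond the scatter. From the compounds shown here alone, whether methoxy behaves the same on other aromatic carbons also stays open.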